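A few compounds are considered here, and "the series" means these few. Any claim that something is new, unique, unknown or untested is made for them only; others in the source may bear on it.

In an in vitro assay on BL21-DE3 cells for displacement of a labelled ligand from thyroid hormone receptor beta (Homo sapiens), read by fluorescence polarization (a higher number here means a weaker inhibitor, a lower number a stronger inhibitor), compound 1, `CCCCCCc1ccc(C(=O)/C=C\C(=O)O)cc1`, gives 17700 nM, the second highest of the three numbers recorded. Its nearest neighbour is compound 3, `C=CC(=O)Oc1ccccc1CCCCCC`, which gives 8200 nM in this assay, a gap beyond the scatter; the furthest is compound 2, `C=CC(=O)c1ccc(CCC)cc1`, which gives 100000 nM, also beyond the scatter. Compound 4, `CCCCCCc1ccc(C(=O)C2CO2)cc1`, has not yet been measured. It differs from compound 1 by a single change: oxiran-2-yl in place of 2-carboxyethenyl on a carbonyl carbon. Nothing measured here tracks this exchange, so the direction is uncertain; the step from compound 1 to compound 4 is expected to be a 1.1-fold higher number from compound 1 to compound 4 (0.05 log units; within the scatter), no larger than the scatter of repeated measurements. For compound 4 the value in this assay is estimated at 20000 nM, with a likely range from 7000 nM to 60000 nM.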

Compound 4, half-maximal inhibitory concentration: 19100 nM
Beside the measured number, compound 4's estimate is 1.0-fold (0.02 log units) above it; the measured number falls inside the stated range.
By their numbers in this assay, from the lowest: compound 3; then compounds 1 and 4 (each within the scatter of the next); then compound 2.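

Among the compounds shown here, replacing 2-carboxyethenyl with oxiran-2-yl on a carbonyl carbon whose other neighbour is an aromatic carbon gives a 1.1-fold higher number from compound 1 to compound 4 (0.03 log units; within the scatter) in this assay and is the first step that can be read at this place. A three-membered ring with one hetero atom and no hydrogen-bond donor thus reads the same, within the scatter, as an open group with two double bonds and one donor. Nothing measured here explains this match. Going by these compounds, whether an amine or a saturated chain ending in a carboxylic acid would read the same on this carbonyl carbon stays open.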